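The source may report more compounds than this note shows. Statements on the series, on what has been measured and on what is new or still open speak of the compounds shown alone.

Measured in an ADME assay on the whole organism for inhibition, with Oryza sativa as the target, with a stated time of 4 days; on this read-out lower numbers stand for stronger inhibition and higher numbers for weaker inhibition:
Compound 1 `CCCN(CC)c1nc(Cl)nc(N[C@@H](C)c2ccccc2)n1`: 479 nM
Compound 2 `CCCN(CC)c1nc(Cl)nc(N[C@H](C)c2ccccc2)n1`: 24500 nM

Of these two, compound 1 holds the lower number. Compound 3 (`CCCN(C)c1nc(Cl)nc(N[C@@H](C)c2ccccc2)n1`) differs from compound 1 at one place: hydrogen in place of methyl on a saturated chain carbon bound to a nitrogen on an aromatic ring. In other words, ethyl(propyl)amino becomes methyl(propyl)amino. Among the compounds with values here, the only measured step, a 51-fold higher number from compound 1 to compound 2 (1.71 log units; beyond the scatter), is large, but it bears on this change only loosely, given (the fact that compounds 1 and 2 differ only in the configuration as drawn). Within the data shown here, no measured step touches this chain, so only a small rise in the number is expected, with little confidence in its size. The estimated step is a 1.7-fold higher number from compound 1 to compound 3 (0.22 log units; within the scatter). For compound 3 the expected value is 800 nM, with an estimated range of 250 nM to 2500 nM.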

Compound 3, half-maximal inhibitory concentration: 5500 nM
Beside the measured number, compound 3's estimate is 6.9-fold (0.84 log units) below it; the measured number lies above the stated range.
By their numbers in this assay, from the lowest: compound 1; then compound 3; then compound 2.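

In this assay, going from ethyl(propyl)amino to methyl(propyl)amino gives an 11-fold higher number from compound 1 to compound 3 (1.06 log units; beyond the scatter) and counts as a large step, beyond the scatter. The loss of one carbon from this chain therefore matters a great deal here, and the stereocentre is not the only place where a small edit moves the number strongly. Nothing known here explains the size of this step.

As far as these compounds go, it remains open whether a longer chain, such as butyl in place of ethyl, would lower the number or raise it. From the compounds shown here alone, the effect of changing the propyl group also remains open.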